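Bromo for methoxy on the benzyl ring of compound 2

The source may report more compounds than this note shows. Statements on the series, on what has been measured and on what is new or still open speak of the compounds shown alone.

For the measured compounds named here, compound 2 `COc1ccccc1CC1(OC)CCN(c2ccc(C(=O)NS(=O)(=O)c3ccc(N[C@H](CCN(C)C)CSc4ccccc4)c([N+](=O)[O-])c3)cc2)CC1` gives 250 nM in a functional assay (FL5.12 cells, Mus musculus) with Apoptosis regulator Bcl-2 (Homo sapiens) as the target (on this read-out lower numbers stand for an effect already at smaller amounts and higher numbers for an effect only at larger amounts of compound), and sits at the top of the two numbers so far, though the gap to compound 1 `COC1(Cc2ccccc2C)CCN(c2ccc(C(=O)NS(=O)(=O)c3ccc(N[C@H](CCN(C)C)CSc4ccccc4)c([N+](=O)[O-])c3)cc2)CC1`, which gives 200 nM, lies within the scatter. Compound 3 `COC1(Cc2ccccc2Br)CCN(c2ccc(C(=O)NS(=O)(=O)c3ccc(N[C@H](CCN(C)C)CSc4ccccc4)c([N+](=O)[O-])c3)cc2)CC1` differs from compound 2 by bromo in place of methoxy on an aromatic carbon. Going by the values given here, the one measured step at this carbon, a 1.3-fold higher number from compound 1 to compound 2 (0.10 log units; within the scatter), stayed within the scatter, so the swap is expected to change the number by no more than that, a 1.1-fold lower number from compound 2 to compound 3 (0.06 log units; within the scatter). Compound 3 is accordingly estimated at 220 nM in this assay, with a range from 100 nM to 500 nM.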

Compound 3, half-maximal effective concentration: 200 nM
Estimate against measurement, compound 3: 1.1-fold (0.04 log units) above; low and high end bracket the measured number.
By their numbers in this assay, from the lowest: compounds 1, 3 and 2 (each within the scatter of the next).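

Two further steps at this aromatic carbon (a 1.3-fold lower number from compound 2 to compound 3 (0.10 log units; within the scatter) with bromo in place of methoxy; no change at the digits printed from compound 1 to compound 3 (within the scatter) with bromo in place of methyl) both lie within the scatter. In this assay methyl, methoxy and bromo at this carbon thus stay within the scatter of one another, so a halogen here reads the same as the two earlier groups. No supporting data on hand accounts for this result.

On these data alone, whether the number stays this flat with an amine, a carboxylic acid or a longer chain on this carbon remains open. Also open, as far as these compounds go, is whether bromo on another carbon of the same ring reads the same.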